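A few compounds are considered here, and "the series" means these few. Any claim that something is new, unique, unknown or untested is made for them only; others in the source may bear on it.

Working notes on the series. Three compounds have numbers in a functional assay on PC-3 cells (Homo sapiens) for antiproliferative activity, read by MTT assay, tested at 1 uM; a higher number here means a stronger effect of the compound at the concentration tested, a lower number a weaker effect. Compound 1 `COc1cc(C2=NN(C(C)=O)C(c3cccc(F)c3)O2)cc(OC)c1OC` gives 16.5%. Compound 2 `COc1cc(C(=O)N/N=C/c2ccccc2F)cc(OC)c1OC` gives 70.6%, and compound 3 `COc1ccc(/C=N/NC(=O)c2cc(OC)c(OC)c(OC)c2)c(OC)c1` gives 10%. Among these three numbers compound 1 stands second highest. Its nearest neighbour is compound 3, whose number lies within the usual scatter of that of compound 1, so the two are not distinguished. Compound 2 stands far above compound 1, beyond the scatter. For the measured compounds named here, no two measured compounds differ in a single place, so no single-point step is available for the core of compound 1.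

Compound 4 `COc1cc(C2=NN(C(C)=O)C(c3ccc(F)c(F)c3)O2)cc(OC)c1OC` is not yet measured in this assay. It differs from compound 1 in one place: fluoro in place of hydrogen on an aromatic carbon. Going by the values given here, no measured pair shows what this change does on this core, so nothing in the data supports a step in either direction beyond the scatter. The expected step is small, a number 3.5 percentage points higher from compound 1 to compound 4 (within the scatter), which is none beyond the scatter. Compound 4 is estimated at 20%, with a range from 5% to 40%.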

Compound 4, a percentage reported as inhibition, at one concentration (the size of the read-out at that concentration, not a potency): 35.5%
For compound 4 the middle estimate is 15.5 percentage points below the measured one; low and high end bracket the measured number.
By their numbers in this assay, from the lowest: compounds 3 and 1 (each within the scatter of the next); then compound 4; then compound 2.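

Fluoro in place of hydrogen on an aromatic carbon, ortho to a fluoro group and para to a large group, gives the first single-place step of the series in this assay, a number 19 percentage points higher from compound 1 to compound 4 (beyond the scatter). For the compounds shown here, the step is modest, but it shows that the read-out on this core responds to a change at this position and that, for 3-fluorophenyl to 3,4-difluorophenyl, it moves upward, a direction the earlier compounds could not show. No measurement on hand bears on the origin of this step.

On these data alone, it remains open whether the rise is specific to fluoro or would also appear with another group at this position, such as chloro, methoxy or an amine. As far as these compounds go, it is also open whether the same change would give a similar step on a different core.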